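Trifluoromethyl for cyano on the anilide ring

This account rests on a few compounds, and the source may have more. Where it says the series, first, only, none or still open, it means among the compounds named here.

In an ADME assay on THP-1 cells (Homo sapiens) for cytotoxicity (on this read-out higher numbers stand for lower toxicity in this test and lower numbers for higher toxicity in this test), compound 1 `O=C(Nc1ccc(Cl)cc1)c1c(NC(=O)C(F)(F)F)sc2c1CCCCC2` gives > 50000 nM, which is a limit of the assay and not a number. Within the data shown here, compound 2 `N#Cc1ccc(NC(=O)c2c(NC(=O)C(F)(F)F)sc3c2CCCCC3)cc1` gives 9110 nM, the only true number so far. Cyano in place of chloro on an aromatic carbon makes an at least 5.4-fold lower number from compound 1 to compound 2 (0.73 log units; beyond the scatter), and the size of that step is only a bound because of the limit of > 50000 nM in this assay, at which 1 of the 2 values shown sits.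

Compound 3 `O=C(Nc1ccc(C(F)(F)F)cc1)c1c(NC(=O)C(F)(F)F)sc2c1CCCCC2` keeps the shared core and has trifluoromethyl in place of cyano on an aromatic carbon, para to a large group: trifluoromethyl in place of cyano on an aromatic carbon. Among the measured compounds shown here, the one measured step bearing on this change is at the same kind of carbon and also involves cyano. For the measured compounds named here, compound 2 took its lower number in an at least 5.4-fold lower number from compound 1 to compound 2 (0.73 log units; beyond the scatter), so removing cyano is expected to give back part of that step, though no measured step involves trifluoromethyl. The expected change is a 2.2-fold higher number from compound 2 to compound 3 (0.34 log units; beyond the scatter), a modest estimated rise in this assay that may not clear the scatter. For compound 3 the estimated value is 20000 nM, with an expected range from 7000 nM to 55000 nM.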

Compound 3, half-maximal cytotoxic concentration: 17200 nM
The estimate for compound 3 lay 1.2-fold (0.07 log units) above the measured number, within the range that was stated.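

In this assay, 4-(trifluoromethyl)phenyl in place of 4-cyanophenyl gives a 1.9-fold higher number from compound 2 to compound 3 (0.28 log units; within the scatter), so compound 2 and compound 3 cannot be told apart on this read-out. Trifluoromethyl in place of chloro at the same carbon gives an at least 2.9-fold lower number from compound 1 to compound 3 (0.46 log units; beyond the scatter), which lies beyond the scatter, as does the cyano replacement, an at least 5.4-fold lower number from compound 1 to compound 2 (0.73 log units; beyond the scatter), so the lower number relative to compound 1 is no longer seen with cyano alone. The true size of both steps from compound 1 remains unknown, because compound 1 stands at a limit of the assay and not at a number: the limit of > 50000 nM in this assay, at which 1 of the 3 values shown sits.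

On these data alone, how far compound 1 actually lies from compound 2 and compound 3 stays open, and the three compounds do not show which feature of the groups at this carbon goes with the lower numbers. As far as these compounds go, whether an amine, a carboxylic acid or a methoxy group at this carbon would stay with compound 2 and compound 3 or move toward the limit seen for compound 1 also remains open.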